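Methyl in place of phenolic hydrogen across two cores

A few compounds are considered here, and "the series" means these few. Any claim that something is new, unique, unknown or untested is made for them only; others in the source may bear on it.

Compound 1 `COc1cc2occ(-c3csc4ccccc34)c(=O)c2c(OC)c1OC` gives 740 nM in a functional assay on MCF7 cells (Homo sapiens) for antiproliferative activity, read by sulforhodamine B assay, with a stated time of 72 h; on this read-out higher numbers stand for weaker inhibition and lower numbers for stronger inhibition. For compound 2 `COc1cc2occ(-c3csc4ccccc34)c(=O)c2c(OC)c1O` this assay reports only a limit, > 10000 nM. The change methyl in place of hydrogen on an oxygen on an aromatic ring therefore brings an at least 13-fold lower number from compound 2 to compound 1 (1.13 log units; beyond the scatter), the measured value of compound 2 being the limit (the limit of > 10000 nM in this assay, at which 1 of the 3 values shown sits). Compound 3 `COc1ccc(O)c(C(=O)/C=C/c2csc3ccccc23)c1` gives 750 nM in this assay; how its core differs from that of compound 2 is not broken down here. Compound 4 `COc1ccc(OC)c(C(=O)/C=C/c2csc3ccccc23)c1` is not yet measured and differs from compound 3 by methyl in place of hydrogen on an oxygen on an aromatic ring, the same change as that from compound 2 to compound 1. Because of an at least 13-fold lower number from compound 2 to compound 1 (1.13 log units; beyond the scatter) a large step toward a lower number is expected, estimated as a 3.8-fold lower number from compound 3 to compound 4 (0.57 log units; beyond the scatter). Compound 4 is thus expected to give about 200 nM in this assay, between 50 nM and 900 nM.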

Compound 4, half-maximal inhibitory concentration: 5500 nM
Compound 4: the middle estimate sits 28-fold (1.44 log units) below what was measured, and the stated range ends below it.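

In this assay, hydroxy to methoxy on the core of compound 3 brings a 7.3-fold higher number from compound 3 to compound 4 (0.87 log units; beyond the scatter), so the change did not carry over from the core of compound 2 in size or direction: (the same change on two cores in this assay, an at least 13-fold lower number (1.13 log units; beyond the scatter) from compound 2 to compound 1 and a 7.3-fold higher number (0.87 log units; beyond the scatter) from compound 3 to compound 4, at least 99-fold (1.99 log units) apart, beyond the scatter of two such steps). Compound 2 gives > 10000 nM, which is a limit and not a number. These results show that the effect of this change depends on the core here, but not which feature of the two cores sets its direction, and two cores give no rule for a third.

The compounds shown leave open how a longer chain on that oxygen would behave on either core. They also leave open what an amine in place of the hydroxy group would do.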